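Compound 3 to compound 4: fluoro in place of chloro

The source may hold more compounds than are shown below. What is called first, only, known or untested is meant among the compounds shown, and "the series" means these compounds.

In a functional assay on C6 cells (Rattus norvegicus) for cytotoxicity, read by MTT assay, with a stated time of 24 h (on this read-out higher numbers stand for weaker inhibition and lower numbers for stronger inhibition), compound 3 `O=C(CSc1ncccn1)N/N=c1/scc(-c2ccc(Cl)cc2)n1-c1ccccc1` gives 83.3 ug/mL, the higher of the two numbers available. Compound 1 `Cc1nnc(SCC(=O)N/N=c2/scc(-c3ccc(F)cc3)n2-c2ccccc2)s1` gives 27.3 ug/mL, lower by more than the scatter, although it also differs from compound 3 elsewhere in the structure. For compound 2 `N#Cc1ccc(-c2cs/c(=N/NC(=O)CSc3ncccn3)n2-c2ccccc2)cc1` the entry reads "not determined" (no result reported). Compound 4 `O=C(CSc1ncccn1)N/N=c1/scc(-c2ccc(F)cc2)n1-c1ccccc1`, not yet measured, differs from compound 3 by fluoro in place of chloro on an aromatic carbon. For the measured compounds named here, no measured pair isolates this change, so no step beyond the scatter is expected in this assay. A slight lean towards a lower number is expected because compound 1 with its 4-fluorophenyl gives 27.3 ug/mL. The expected change is a 1.4-fold lower number from compound 3 to compound 4 (0.14 log units; within the scatter). For compound 4 the estimated value is 60 ug/mL, with an expected range from 25 ug/mL to 150 ug/mL.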

Compound 4, half-maximal inhibitory concentration: 110 ug/mL
The estimate for compound 4 lay 1.8-fold (0.26 log units) below the measured number, within the range that was stated.
By their numbers in this assay, from the lowest: compound 1; then compounds 3 and 4 (each within the scatter of the next).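

Fluoro and chloro on the aromatic carbon are not told apart in this assay (a 1.3-fold higher number from compound 3 to compound 4 (0.12 log units; within the scatter)), so with the pyrimidin-2-yl on the sulfur this change leaves the number within the scatter. The larger step belongs to the group on the sulfur, where pyrimidin-2-yl in place of 5-methyl-1,3,4-thiadiazol-2-yl gives a clear rise (a 4.0-fold higher number from compound 1 to compound 4 (0.61 log units; beyond the scatter)). Nothing measured here accounts for either step.

As far as these compounds go, it remains open whether a methoxy group or an amine in that aromatic place would move the number. Also open, from the compounds shown here alone, is whether the step at the sulfur holds with 4-chlorophenyl.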